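A few compounds are considered here, and "the series" means these few. Any claim that something is new, unique, unknown or untested is made for them only; others in the source may bear on it.

Measured so far in an assay for binding affinity to adenosine receptor A1 (Bos taurus); a higher number here means a weaker inhibitor, a lower number a stronger inhibitor:
Compound 1, `Cc1ccc2c(O)c(C(=O)NCc3ccc([N+](=O)[O-])cc3)cnc2n1`: 1630 nM.
Compound 2, `CC(=O)Nc1ccc2c(O)c(C(=O)NCc3ccccc3)cnc2n1`: > 10000 nM, which is a limit of the assay rather than a number.

Compound 2 thus stands at the limit of this assay, as the limit of > 10000 nM in this assay, at which 1 of the 2 values shown sits, records, and offers no number to set against compound 1. Compound 3, `CN(C)c1ccc2c(O)c(C(=O)NCc3ccccc3)cnc2n1`, differs from compound 2 in one place: dimethylamino in place of acetamido on an aromatic carbon. Among the compounds with values here, no step between measured compounds involves this exchange, so the size and direction of the change rest on nothing measured here. With compound 2 at the limit, the measurement of compound 3 is about as likely to return a limit as a number. Compound 3 is expected to come in around 8000 nM in this assay, within a range from 2000 nM to 30000 nM. This estimate means an expected step of an at least 1.2-fold lower number from compound 2 to compound 3 (0.09 log units; that floor lies within the scatter), small if any beyond the usual scatter, and more likely toward stronger than weaker binding.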

Compound 3, inhibition constant: 122 nM
Beside the measured number, compound 3's estimate is 66-fold (1.82 log units) above it; measured number below the stated range.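

Replacing acetamido with dimethylamino on this aromatic carbon, next to the ring nitrogen, gives the first readable result for this position in this assay: an at least 81-fold lower number from compound 2 to compound 3 (1.91 log units; beyond the scatter). With the rest of the molecule unchanged, the group on this carbon clearly matters for binding, and compound 3 reaches 122 nM. The size of the step is only a minimum, because compound 2 stands at a limit of the assay rather than at a number: the limit of > 10000 nM in this assay, at which 1 of the 3 values shown sits.

This single exchange cannot separate the effect of losing the hydrogen-bond donor and the double bond outside aromatic rings from that of the dimethylamino group itself. From the compounds shown here alone, whether a methylamino group or a plain amine on this carbon would match compound 3 remains open.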